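Series notes: aryl swap on the alkene carbon

The source may hold more compounds than are shown below. What is called first, only, known or untested is meant among the compounds shown, and "the series" means these compounds.

Measured so far:
compound 1, `O=C(O)/C=C/c1ccc(/C(=C(/CCF)c2ccccc2)c2ccc3[nH]ncc3c2)cc1`: 2.1 nM
compound 2, `CC/C(=C(/c1ccc(/C=C/C(=O)O)cc1)c1ccc2[nH]nc(C)c2c1)c1ccccc1`: reported only as a limit, > 1000 nM
compound 3, `CS(=O)(=O)c1ccc(/C(=C(\c2ccc(/C=C/C(=O)O)cc2)c2ccc3[nH]nc(F)c3c2)C2CCC2)c(Cl)c1`: 2.3 nM

In a functional assay on MCF7 cells (Homo sapiens) for cytotoxicity, read by CellTiter-Glo, with a stated time of 5 days (a lower number here means a stronger inhibitor, a higher number a weaker inhibitor), compound 3 gives 2.3 nM, the higher of the two numbers shown, yet within the scatter of compound 1 at 2.1 nM. The value of compound 2 is a limit of the assay, not a number.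

Compound 4, `N#Cc1cc(Cl)cnc1/C(=C(\c1ccc(/C=C/C(=O)O)cc1)c1ccc2[nH]nc(F)c2c1)C1CCC1`, is not yet measured. It differs from compound 3 by 5-chloro-3-cyanopyridin-2-yl in place of 2-chloro-4-(methylsulfonyl)phenyl on a double-bonded chain carbon bound to a double-bonded chain carbon and a saturated ring carbon. Going by the values given here, no pair of measured compounds covers a change of this kind, so no guidance on direction exists; the working expectation is no shift beyond the scatter. The expected step is a 1.3-fold higher number from compound 3 to compound 4 (0.12 log units; within the scatter). Compound 4 is estimated at 3 nM, with a range from 1 nM to 12 nM.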

Compound 4, half-maximal inhibitory concentration: 1.1 nM
Estimate against measurement, compound 4: 2.7-fold (0.44 log units) above; measured number inside the range.
By their numbers in this assay, from the lowest: compounds 4, 1 and 3 (each within the scatter of the next, the first and the last beyond it). At a limit, above all of these: compound 2.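

At the place on a double-bonded chain carbon bound to a double-bonded chain carbon and a saturated ring carbon, this assay now has its first readable step, with 5-chloro-3-cyanopyridin-2-yl in place of 2-chloro-4-(methylsulfonyl)phenyl giving a 2.1-fold lower number from compound 3 to compound 4 (0.32 log units; beyond the scatter) on this change. Low numbers at this place therefore need neither methylsulfonyl nor a ring of carbon only. No measurement shown bears on the cause of the step.

Which part of the new group accounts for the step stays open, since chlorine, nitrile and ring nitrogen are not separated here. On these data alone, how an amine or a methoxy group would read at this place also stays open.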